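Allyl in Place of Nitrophenyl on the Ring Nitrogen

The source may hold more compounds than are shown below. What is called first, only, known or untested is meant among the compounds shown, and "the series" means these compounds.

Compound 1 `O=c1c2ccccc2c(Cc2ccc(Cl)cc2)nn1-c1ccc([N+](=O)[O-])cc1`: in a functional assay on aorta with Alpha-1D adrenergic receptor (Rattus norvegicus) as the target (a lower number here means that less compound is needed, a higher number that more compound is needed for the effect), compound 1 gives 29000 nM.
Compound 2 `CSc1ccc(Cc2nn(-c3ccc([N+](=O)[O-])cc3)c(=O)c3ccccc23)cc1`: in this assay compound 2 reaches only the limit of > 100000 nM, a limit of the assay and not a number.

Compound 2 stands at the top of the two numbers shown; it sits at the limit of > 100000 nM in this assay, at which 1 of the 2 values shown sits. Among the measured compounds shown here, the only measured step, an at least 3.4-fold higher number from compound 1 to compound 2 (0.53 log units; beyond the scatter), concerns the methylsulfanyl that replaces chloro on an aromatic carbon, and it runs toward weaker activity.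

Compound 3 `C=CCn1nc(Cc2ccc(SC)cc2)c2ccccc2c1=O` differs from compound 2 by allyl in place of 4-nitrophenyl on an aromatic nitrogen. For the measured compounds named here, no measured step touches this aromatic nitrogen, so the step from compound 1 to compound 2 offers no guide for its direction or size. Since compound 2 rests at a limit, a further rise cannot be seen, and a fall would have to exceed the scatter to register at all. In this assay compound 3 is estimated at 100000 nM, with a range from 20000 nM to 400000 nM. This estimate amounts to an expected step of a number no higher from compound 2 to compound 3 (the limit leaves the size open), with the number most likely again reported only as a limit.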

Compound 3, half-maximal effective concentration: > 100000 nM
Compound 3: a limit, no number; the forecaster's own chance of this, stated with the estimate: 60%; the middle value lies on the limit itself.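

In this assay compound 3 gives > 100000 nM, a limit of the assay and not a number. Compound 2 also rests at a limit, so no new step can be read between compound 2 and compound 3: the limit of > 100000 nM in this assay, at which 2 of the 3 values shown sit. The compounds shown leave open whether allyl or 4-nitrophenyl on the aromatic nitrogen gives the lower number.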